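Swapping a Benzoyl End for a Dimethyl Acetal

The source may report more compounds than this note shows. Statements on the series, on what has been measured and on what is new or still open speak of the compounds shown alone.

Of the compounds shown here, two have been measured in an assay on isolated protein for inhibition of Fatty-acid amide hydrolase 1 (Homo sapiens); a higher number here means a weaker inhibitor, a lower number a stronger inhibitor. Compound 1 `CCCCCCCC/C=C\CCCCCCC(=O)c1ccccc1` carries a long chain with one double bond and ends in a benzoyl group. In this assay compound 1 gives > 100000 nM, which is a limit of the assay rather than a number. Compound 1 thus sits at the limit of > 100000 nM in this assay, at which 1 of the 2 values shown sits, and its true inhibition constant is not known. Compound 2 `O=C(CCCC[S+]([O-])Cc1ccccc1)c1ncc(-c2ccccn2)o1`, built on a different core, gives 2500 nM in this assay. Compound 3 `CCCCCCCC/C=C\CCCCCCCC(OC)OC` has not yet been measured; it differs from compound 1 by 2,2-dimethoxyethyl in place of benzoyl on a saturated chain carbon, six bonds along the chain from a double-bonded chain carbon. For the measured compounds named here, no step between two measured compounds is known here, so the size of this change can only be estimated. The step from compound 1 to compound 3 is expected to be a number no higher from compound 1 to compound 3 (the limit leaves the size open) because compound 1 already sits at the limit of > 100000 nM in this assay, at which 1 of the 2 values shown sits, and nothing known points to a gain. Compound 3 is therefore expected to give about 100000 nM, between 20000 nM and 500000 nM, and quite possibly again only a limit.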

Compound 3, inhibition constant: > 300000 nM
Compound 3: a limit, no number (the forecaster's own chance of this, stated with the estimate: 70%); middle value at least 3.0-fold (0.47 log units) from the limit.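

For the compounds shown here, compound 1 and compound 3 each give only a limit of the assay, and no step between them can be read from two limits. Going by these compounds, how strongly either compound truly inhibits, and whether 2,2-dimethoxyethyl in place of benzoyl changes that at all, stays open.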